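Compound 4: Replacing One Ring Nitrogen with Carbon

This account rests on a few compounds, and the source may have more. Where it says the series, first, only, none or still open, it means among the compounds named here.

Measured compounds and their values:
Compound 1 `Cn1c(=O)c(S(=O)(=O)c2ccc(Cl)cc2)cc2cnc(Nc3ccc4[nH]ccc4c3)nc21` — 250 nM
Compound 2 `Cn1c(=O)c(S(=O)(=O)c2ccc(O)cc2)cc2cnc(Nc3ccc4[nH]ccc4c3)nc21` — 250 nM
Compound 3 `Cn1c(=O)c(S(=O)(=O)c2ccc(F)cc2)cc2cnc(Nc3cnc4[nH]ccc4c3)nc21` — 500 nM

In a functional assay on DU-145 cells (Homo sapiens) for inhibition, read by trypan blue exclusion, with a stated time of 72 h (on this read-out lower numbers stand for stronger inhibition and higher numbers for weaker inhibition), compound 3 gives 500 nM, the highest of the three numbers, though compound 1 at 250 nM and compound 2 at 250 nM both lie within the scatter of it, so none of the three can be set apart from the others.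

Compound 4 `Cn1c(=O)c(S(=O)(=O)c2ccc(F)cc2)cc2cnc(Nc3ccc4[nH]ccc4c3)nc21` differs from compound 3 in one place: a group of 9 heavy atoms (8 carbon, 1 nitrogen; one five-membered aromatic ring with 1 hetero atom, one six-membered aromatic ring of carbon only) in place of a group of 9 heavy atoms (7 carbon, 2 nitrogen; one five-membered aromatic ring with 1 hetero atom, one six-membered aromatic ring with 1 hetero atom), on a nitrogen on an aromatic ring. Among the measured compounds shown here, the only measured step, no change at the digits printed from compound 1 to compound 2 (within the scatter), concerns a substituent on an aromatic carbon of a different part of the shared core and does not bear on this change. What does bear on it is that compound 1 and compound 2 already carry 1H-indol-5-yl on that nitrogen, and their numbers sit within the scatter of compound 3. No step beyond the scatter is therefore expected in this assay. Compound 4 is expected to give 300 nM, with a range from 120 nM to 750 nM. The expected step of a 1.7-fold lower number from compound 3 to compound 4 (0.22 log units; within the scatter) stays within the scatter.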

Compound 4, half-maximal inhibitory concentration: 300 nM
For compound 4 middle estimate and measured number coincide at the digits printed; low and high end bracket the measured number.
By their numbers in this assay, from the lowest: compounds 1, 2, 4 and 3 (each within the scatter of the next).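

With the fluoro group held fixed, exchanging the group carrying a second ring nitrogen for 1H-indol-5-yl on the nitrogen on an aromatic ring stays within the scatter in this assay (a 1.7-fold lower number from compound 3 to compound 4 (0.22 log units; within the scatter)), so this one ring atom makes no readable difference here. Compound 4 also adds the fluoro group to the chloro and hydroxy groups already held by the 1H-indol-5-yl compounds, and neither exchange leaves the scatter (a 1.2-fold higher number from compound 2 to compound 4 (0.08 log units; within the scatter); a 1.2-fold higher number from compound 1 to compound 4 (0.08 log units; within the scatter)). No measurement shown here offers an explanation for these results.

On these data alone, it remains open whether this nitrogen would tolerate a plain phenyl ring, or a phenyl ring carrying an amine or a carboxylic acid, with equally small steps. The compounds shown also leave untested whether a longer chain in place of the methyl group on the shared core would change the number.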